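2-Cyclohexylethyl to benzyl on the aromatic nitrogen

The source may report more compounds than this note shows. Statements on the series, on what has been measured and on what is new or still open speak of the compounds shown alone.

In an ADME assay on Huh-7 cells (Homo sapiens) for cytotoxicity, with a stated time of 72 h (a lower number here means that less compound is tolerated, a higher number that more compound is tolerated), compound 2 `CS(=O)(=O)Nc1ccc2c(c1)S(=O)(=O)N=C(c1c(O)c(-c3cccs3)nn(CCC3CCCCC3)c1=O)N2` gives > 17000 nM, which is a limit and not a number. Compound 1 `CCCC(C)n1nc(-c2cccs2)c(O)c(C2=NS(=O)(=O)c3cc(NS(C)(=O)=O)ccc3N2)c1=O` gives > 33000 nM, also a limit. Within the data shown here, the only measured step bearing on the change is a step that the two limits leave unreadable from compound 1 to compound 2, with 2-cyclohexylethyl in place of 1-methylbutyl on an aromatic nitrogen. Compound 3 `CS(=O)(=O)Nc1ccc2c(c1)S(=O)(=O)N=C(c1c(O)c(-c3cccs3)nn(Cc3ccccc3)c1=O)N2` carries phenyl in place of cyclohexylmethyl on a saturated chain carbon bound to an aromatic nitrogen. With no readable size to carry over, no step beyond the scatter is expected in this assay, in either direction: a step that the limit leaves unreadable from compound 2 to compound 3. Compound 3 is estimated at 30000 nM, within 12000 nM to 60000 nM.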

Compound 3, half-maximal cytotoxic concentration: > 1000 nM
Compound 3: only a limit was reported (the forecaster's own chance of this, stated with the estimate: 70%); the middle value is on the limit's open side.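

In this assay compound 3 gives > 1000 nM, which is a limit. Among these compounds, compound 1 and compound 2 also stand only as limits, so no step among the three can be read. From the compounds shown here alone, whether benzyl, 2-cyclohexylethyl or 1-methylbutyl on the aromatic nitrogen changes the tolerated concentration remains open.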